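A few compounds are considered here, and "the series" means these few. Any claim that something is new, unique, unknown or untested is made for them only; others in the source may bear on it.

The three measured compounds share one core and differ only in the group on one aromatic carbon of the fused ring. Compound 1 `CN1CCN(CCCN(C(=O)Nc2ccc(F)c(Cl)c2)C2CCc3ccccc3C2)CC1` carries a hydrogen at that position; in an assay on CHO cells for binding affinity to melanin-concentrating hormone receptor 1 (Homo sapiens) (on this read-out lower numbers stand for stronger inhibition and higher numbers for weaker inhibition), compound 1 gives 380 nM. Compound 2 `COc1ccc2c(c1)CC(N(CCCN1CCN(C)CC1)C(=O)Nc1ccc(F)c(Cl)c1)CC2` carries a methoxy group there, and in this assay compound 2 gives 92 nM. Compound 3 `CNS(=O)(=O)c1ccc2c(c1)CC(N(CCCN1CCN(C)CC1)C(=O)Nc1ccc(F)c(Cl)c1)CC2` carries a methylsulfamoyl group, and in this assay compound 3 gives 3000 nM. Among these three numbers compound 1 stands second highest: the nearer step is a 4.1-fold lower number from compound 1 to compound 2 (0.62 log units; beyond the scatter), the further one is a 7.9-fold higher number from compound 1 to compound 3 (0.90 log units; beyond the scatter), and between the two substituted analogues the step is a 33-fold higher number from compound 2 to compound 3 (1.51 log units; beyond the scatter).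

Compound 4 `CC(=O)Nc1ccc2c(c1)CC(N(CCCN1CCN(C)CC1)C(=O)Nc1ccc(F)c(Cl)c1)CC2` is the unmeasured member; the change from compound 1 is acetamido in place of hydrogen on an aromatic carbon. Both substitutions already measured at this carbon moved the number beyond the scatter, but in opposite directions, so the direction for an acetamido group is not settled by the data. The acetamido group is counted with one hydrogen-bond donor and one hydrogen-bond acceptor, which places it between the methoxy of compound 2 and the methylsulfamoyl of compound 3. The account therefore expects for compound 4 a modest step, leaning toward the weaker side, of a 1.6-fold higher number from compound 1 to compound 4 (0.20 log units; within the scatter). In this assay compound 4 is estimated at 600 nM, with a range from 150 nM to 2500 nM.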

Compound 4, inhibition constant: 6 nM
For compound 4 the middle estimate is 100-fold (2.00 log units) above the measured one; the whole stated range lies above it.
By their numbers in this assay, from the lowest: compound 4; then compound 2; then compound 1; then compound 3.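

In this assay, the acetamido group gives the largest gain seen at this aromatic carbon (a 63-fold lower number from compound 1 to compound 4 (1.80 log units; beyond the scatter)), showing that a substituent here can lower the number much further than the methoxy group of compound 2 had indicated. The identity of the entering group matters greatly at this one carbon, as the same core spans a 15-fold lower number from compound 2 to compound 4 (1.19 log units; beyond the scatter) and, against the methylsulfamoyl group, a 500-fold lower number from compound 3 to compound 4 (2.70 log units; beyond the scatter); these are changes at a single place, and neither the size nor the direction of the acetamido step could be read from the hydrogen, methoxy and methylsulfamoyl compounds alone. Nothing in the information available here explains why the acetamido group stands so far apart from the other groups at this position.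

The compounds shown do not separate the contribution of the amide hydrogen from that of the carbonyl within the acetamido group. They also leave open how a free amine, a longer acyl chain such as propionamido, or a reversed amide at this same aromatic carbon would read in this assay.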